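The compounds below may be only part of what the source reports. "The series", "measured", "known", "first", "only" and "open" are said of these compounds alone.

The study measures an ADME assay on Vero cells (Chlorocebus sabaeus) for cytotoxicity, read by MTT assay, with a stated time of 72 h; on this read-out higher numbers stand for lower toxicity in this test and lower numbers for higher toxicity in this test. Compound 1, `C[C@]1(CN2CCc3nc(C(F)(F)F)ccc3C2)Cn2cc([N+](=O)[O-])nc2O1`, carries in this assay only the entry "not determined" (no result reported), so no figure exists for it. Compound 2, `C[C@]1(CN2CCc3nc(-c4cc(F)ccc4F)ccc3C2)Cn2cc([N+](=O)[O-])nc2O1`, gives in this assay > 32 ug/mL, which is a limit of the assay rather than a number. Where compound 2 stands is therefore described only by the limit of > 32 ug/mL in this assay, at which 1 of the 2 values shown sits, and nothing closer can be said of it. Compound 3, `C[C@]1(CN2CCc3nc(-c4ccc(Cl)c(F)c4)ccc3C2)Cn2cc([N+](=O)[O-])nc2O1`, has not yet been measured; it differs from compound 2 by 4-chloro-3-fluorophenyl in place of 2,5-difluorophenyl on an aromatic carbon. Going by the values given here, with no measured step between two numbered values to lean on, the expected step is a number no higher from compound 2 to compound 3 (the limit leaves the size open), which is to say none beyond the scatter. Compound 3 is estimated in this assay at 32 ug/mL, with a range from 16 ug/mL to 64 ug/mL, and the assay is expected most likely to report again only a limit.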

Compound 3, half-maximal cytotoxic concentration: > 32 ug/mL
Compound 3 ended at the assay's limit (the forecaster's own chance of this, stated with the estimate: 80%); the middle value sits exactly at the limit.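

Compound 2 and compound 3 each carry only a limit in this assay, so no step can be read between them: the limit of > 32 ug/mL in this assay, at which 2 of the 3 values shown sit.

The compounds shown leave open the actual half-maximal cytotoxic concentration of either compound, and so whether 4-chloro-3-fluorophenyl in place of 2,5-difluorophenyl changes it at all.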